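The source may report more compounds than this note shows. Statements on the series, on what has been measured and on what is new or still open speak of the compounds shown alone.

Measured compounds:
compound 1 `O=C(COc1cccc2ccccc12)N/N=C/c1c(O)ccc2ccccc12` — 1.94 ug/mL
compound 2 `O=C(COc1cccc2ccccc12)N/N=C/c1ccc(Cl)cc1` — 100 ug/mL
compound 3 `O=C(COc1cccc2ccccc12)N/N=C/c1ccc([N+](=O)[O-])cc1` — 14.2 ug/mL

In an ADME assay on HEL cells (Homo sapiens) for cytotoxicity (a higher number here means that more compound is tolerated, a lower number that less compound is tolerated), compound 2 gives 100 ug/mL, the highest of the three numbers; the nearest is compound 3 with 14.2 ug/mL, the furthest compound 1 with 1.94 ug/mL. Within the data shown here, the only single-place step among the measured compounds is a 7.0-fold lower number from compound 2 to compound 3 (0.85 log units; beyond the scatter).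

Compound 4 `O=C(COc1cccc2ccccc12)N/N=C/c1cccc(Br)c1` differs from compound 2 by 3-bromophenyl in place of 4-chlorophenyl on a carbon with a double bond to nitrogen. Among the measured compounds shown here, no measured step exchanges one halogen-bearing phenyl for another. The step from compound 2 to compound 3 shows that a change on the phenyl can move this assay modestly, but nitro is a different kind of group from bromo, so it offers a ceiling rather than a guide. For the measured compounds named here, with no step of the same kind available, the expectation is a small drop at most, within or near the scatter, i.e. a step of about a 1.4-fold lower number from compound 2 to compound 4 (0.15 log units; within the scatter). Compound 4 is therefore estimated at 70 ug/mL, with a range from 30 ug/mL to 100 ug/mL.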

Compound 4, half-maximal cytotoxic concentration: 48.6 ug/mL
The estimate for compound 4 lay 1.4-fold (0.16 log units) above the measured number, within the range that was stated.
By their numbers in this assay, from the lowest: compound 1; then compound 3; then compound 4; then compound 2.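

In this assay, replacing 4-chlorophenyl with 3-bromophenyl on the carbon with a double bond to nitrogen gives a 2.1-fold lower number from compound 2 to compound 4 (0.31 log units; beyond the scatter), so an exchange between two halogen-bearing phenyl groups, with equal heavy-atom counts and no hydrogen-bond donors or acceptors on either side, is enough to pass the scatter. Compound 4 at 48.6 ug/mL still stands above compound 3 at 14.2 ug/mL, so on these numbers the halogen exchange costs less than the nitro exchange, which gave a 7.0-fold lower number from compound 2 to compound 3 (0.85 log units; beyond the scatter). No available evidence bears on the reason for the drop.

The compounds shown do not separate the identity of the halogen from its place on the phenyl, as 3-bromophenyl differs from 4-chlorophenyl in both. As far as these compounds go, how an amine or a carboxylic acid on that phenyl would move this assay also stays open.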